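This account rests on a few compounds, and the source may have more. Where it says the series, first, only, none or still open, it means among the compounds named here.

Measured so far:
- compound 1, `COc1ccc(-c2scc3c2CC(=O)OC32CCN(Cc3ccccc3)CC2)cc1`: 11 nM
- compound 2, `O=C1Cc2cc(-c3ccccc3)sc2C2(CCN(Cc3ccccc3)CC2)O1`: 23 nM
- compound 3, `O=C1Cc2c(-c3ccccc3)csc2C2(CCN(Cc3ccccc3)CC2)O1`: 5.3 nM

In an assay on membranes from brain for displacement of a labelled ligand from Sigma non-opioid intracellular receptor 1 (Cavia porcellus), read by scintillation counting, with a stated time of 120 min (on this read-out lower numbers stand for stronger inhibition and higher numbers for weaker inhibition), compound 3 gives 5.3 nM, the lowest of the three numbers. Compound 1 comes nearest, with a number beyond the scatter above it, and compound 2 stands furthest, also beyond the scatter. Among the measured compounds shown here, compounds 1 and 2 are not single-point neighbours of compound 3, so no direct step to either is defined; their values only show that both sit above compound 3.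

Compound 4, `COc1ccc(-c2csc3c2CC(=O)OC32CCN(Cc3ccccc3)CC2)cc1`, has not been measured. It differs from compound 3 in one place: methoxy in place of hydrogen on an aromatic carbon. For the measured compounds named here, no measured pair isolates this change, so its size has to be estimated from the spread of the numbers already seen. Compound 1, which also carries a 4-methoxyphenyl group on its core, lies close to compound 3, which argues against a large move in either direction. Compound 4 is therefore expected to remain near compound 3, with an estimated step of a 1.1-fold higher number from compound 3 to compound 4 (0.05 log units; within the scatter) that is not beyond the scatter. Compound 4 is estimated at 6 nM in this assay, with a range from 2.5 nM to 16 nM.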

Compound 4, inhibition constant: 43 nM
Beside the measured number, compound 4's estimate is 7.2-fold (0.86 log units) below it; measured number above the stated range.
By their numbers in this assay, from the lowest: compound 3; then compound 1; then compounds 2 and 4 (each within the scatter of the next).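

In this assay, among the compounds shown here, the change from phenyl to 4-methoxyphenyl gives an 8.1-fold higher number from compound 3 to compound 4 (0.91 log units; beyond the scatter), the first step that isolates a single place, and it lies beyond the scatter. On this core, therefore, the aromatic carbon para to a large group is not indifferent to substitution: methoxy in place of hydrogen there weakens inhibition. No measured evidence bears on the origin of this step, so it stands as a description of this one pair.

Still open, on these data alone, is how fluoro, hydroxy or a longer chain such as ethoxy would read on the same carbon, and whether methoxy elsewhere on that ring would give a step of similar size. Also open, as far as these compounds go, is whether phenyl to 4-methoxyphenyl would move the number in the same direction on the core of compound 2.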